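The source may report more compounds than this note shows. Statements on the series, on what has been measured and on what is new or still open speak of the compounds shown alone.

Measured in an ADME assay on HepG2 cells (Homo sapiens) for cytotoxicity, read by MTT assay, with a stated time of 24 h; a higher number here means that more compound is tolerated, a lower number that less compound is tolerated:
Compound 1 `CC1Cn2cc([N+](=O)[O-])nc2O1`: > 500000 nM (a limit)
Compound 2 `CC1Cn2c(nc([N+](=O)[O-])c2Br)O1`: 20100 nM
Compound 3 `CC1Cn2c(nc([N+](=O)[O-])c2-c2ccc(CO)cc2)O1`: > 500000 nM (a limit)

Compound 3 has no exact number and sits at the limit of > 500000 nM in this assay, at which 2 of the 3 values shown sit. Compound 4 `CC1Cn2c(nc([N+](=O)[O-])c2-c2ccc(Cl)cc2)O1` differs from it in one place: chloro in place of hydroxymethyl on an aromatic carbon. Among the compounds with values here, only one measured step bears on this change, and it does so loosely. That step, an at least 24-fold lower number from compound 1 to compound 2 (1.39 log units; beyond the scatter), is a different swap, with bromo replacing hydrogen on an aromatic carbon. It therefore suggests a direction more than a size, and a lower number, with a drop smaller than that step, is expected here. The expected step is an at least 4.1-fold lower number from compound 3 to compound 4 (0.61 log units; beyond the scatter). Compound 4 is estimated at 120000 nM, with an expected range from 25000 nM to 500000 nM.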

Compound 4, half-maximal cytotoxic concentration: > 140000 nM
Compound 4: no number, only a limit; the forecaster's own chance of this, stated with the estimate: 30%; middle value at least 1.1-fold (0.06 log units) from the limit.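

Compound 3 and compound 4 each give only a limit, not a number, and the step between them cannot be read. Going by these compounds, whether chloro in place of hydroxymethyl changes the tolerated concentration at all, and in which direction, stays open.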